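Sulfonyl sulfur change: cyclohexylamino for 4-phenylpiperidin-1-yl

A few compounds are considered here, and "the series" means these few. Any claim that something is new, unique, unknown or untested is made for them only; others in the source may bear on it.

Within the data shown here, in a toxicity assay on Vero cells (Chlorocebus sabaeus) for cytotoxicity, read by MTT assay (on this read-out lower numbers stand for stronger inhibition and higher numbers for weaker inhibition), compound 1 `COC(=O)NC(=O)c1ccsc1NC(=O)c1ccc(S(=O)(=O)N2CCC2)cc1` gives 17.5 ug/mL, the only number so far. Compound 2 `COC(=O)NC(=O)c1ccsc1NC(=O)c1ccc(S(=O)(=O)N2CCC(c3ccccc3)CC2)cc1` has no number to stand on: its entry reads "nd" (no result reported), so it cannot be placed relative to compound 1. Compound 3 `COC(=O)NC(=O)c1ccsc1NC(=O)c1ccc(S(=O)(=O)NC2CCCCC2)cc1` carries cyclohexylamino in place of 4-phenylpiperidin-1-yl on a sulfonyl sulfur. Among the measured compounds shown here, with no result at the compound 2 end, no measured step anchors this change. The nearest reference is the shared core in compound 1 at 17.5 ug/mL, and from that value no step beyond the scatter is expected in this assay, with no direction favoured. The estimate for compound 3 is an expected 15 ug/mL, within an expected range of 5 ug/mL to 45 ug/mL.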

Compound 3, half-maximal inhibitory concentration: > 64 ug/mL
Compound 3 gave a limit, no number; the forecaster's own chance of this, stated with the estimate: 20%; at least 4.2-fold (0.63 log units) between middle value and limit.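

In this assay, cyclohexylamino in place of azetidin-1-yl on a sulfonyl sulfur gives an at least 3.6-fold higher number from compound 1 to compound 3 (0.56 log units; beyond the scatter), so the group on this sulfur does move the read-out, here towards weaker inhibition. Compound 3 gives > 64 ug/mL, which is a limit and not a number: the limit of > 64 ug/mL in this assay, at which 1 of the 3 values shown sits. With no result for compound 2, the change from 4-phenylpiperidin-1-yl to cyclohexylamino cannot be read.

The compounds shown leave open how far the true value of compound 3 lies past its limit, and which feature of cyclohexylamino goes with the higher number. A value for a piperidin-1-yl or a cyclopentylamino group on the same sulfur would bear on the second question.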